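Removing Two Chlorines: From Compound 1 to Compound 4

This account rests on a few compounds, and the source may have more. Where it says the series, first, only, none or still open, it means among the compounds named here.

Of the compounds shown here, three have been measured in a functional assay on cells (T-cell, Homo sapiens) for inhibition; on this read-out higher numbers stand for weaker inhibition and lower numbers for stronger inhibition. Compound 1 `COc1ccc(-c2cnc3nc(N)nc(N4CCN(c5cc(Cl)cc(Cl)c5)CC4)c3n2)cc1OC` gives 3400 nM in this assay. Compound 2 `COc1ccc(-c2cnc3nc(N)nc(NCc4ccccc4)c3n2)cc1OC` gives 13000 nM, and compound 3 `CC(C)Oc1nc(N)nc2ncc(-c3ccc(F)c(F)c3)nc12` gives 10000 nM. Compound 1 thus stands at the lowest number of the three, which on this read-out means the strongest inhibition; its gap to compound 3 and its larger gap to compound 2 both lie beyond the usual scatter of repeated measurements. For the measured compounds named here, no two of these three compounds differ at just one place, so no step between measured compounds can be read off directly.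

Compound 4 `COc1ccc(-c2cnc3nc(N)nc(N4CCN(c5ccccc5)CC4)c3n2)cc1OC` has not yet been measured. It differs from compound 1 in one place only: phenyl in place of 3,5-dichlorophenyl on an amine nitrogen in a ring. The two chlorines are gone and the rest of the structure is kept.

Going by the values given here, no measured pair shows what this particular change does here, so the expectation rests on the structural change alone. For compound 4 the expected step is a 2.1-fold higher number from compound 1 to compound 4 (0.31 log units; beyond the scatter), a modest move toward weaker inhibition, though a result within the scatter would not be surprising. The estimate for compound 4 in this assay is 7000 nM, with a range from 2500 nM to 20000 nM.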

Compound 4, half-maximal inhibitory concentration: 400 nM
Estimate against measurement, compound 4: 18-fold (1.24 log units) above; measured number below the stated range.
By their numbers in this assay, from the lowest: compound 4; then compound 1; then compounds 3 and 2 (each within the scatter of the next).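

Removing the two chlorines from the aromatic ring on the ring amine nitrogen gives an 8.5-fold lower number from compound 1 to compound 4 (0.93 log units; beyond the scatter) in this assay, so on this read-out the change goes with stronger inhibition, not weaker. The step shows that the 3,5-dichlorophenyl group is not needed at this position to reach this level of inhibition, since the plain phenyl group gives the lower number with the rest of the structure unchanged. No measurement bears on why removing the chlorines has this effect, so the step records what happened without explaining it.

The compounds shown leave open whether both chlorines count against inhibition or one alone accounts for most of the step, and a phenyl group carrying a single chlorine would test this directly. They also leave open how other groups on this nitrogen would compare with phenyl, such as a phenyl ring carrying one methyl or one methoxy group, a pyridine ring or a saturated cyclohexyl ring, and whether the same change would give a similar step on a different core.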